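This account rests on a few compounds, and the source may have more. Where it says the series, first, only, none or still open, it means among the compounds named here.

Measured so far:

- Compound 1, `CCOc1ccc(NC(=S)N2CCC(C(O)(c3ccccc3)c3ccccc3)CC2)cc1C#N`: in a functional assay for antagonist activity at Neuropeptide Y receptor type 2 (Homo sapiens) (on this read-out lower numbers stand for stronger inhibition and higher numbers for weaker inhibition), compound 1 gives 323 nM
- Compound 2, `CC(C)Oc1ccc(NC(=S)N2CCC(C(O)(c3ccccc3)c3ccccc3)CC2)cc1C#N`: compound 2 gives 899 nM
- Compound 3, `COc1ccc(OC(=O)N2CCC(C(O)(c3ccccc3)c3ccccc3)CC2)cc1`: compound 3 gives 2680 nM

Compound 4, `CCOc1ccc(OC(=O)N2CCC(C(O)(c3ccccc3)c3ccccc3)CC2)cc1`, has not been measured. It differs from compound 3 in one place: methyl in place of hydrogen on a saturated chain carbon bound to an oxygen on an aromatic ring. The same kind of change has already been measured once, from compound 1 to compound 2, where the difference is methyl in place of hydrogen on a saturated chain carbon bound to an oxygen on an aromatic ring and a saturated chain carbon. That step gave a 2.8-fold higher number from compound 1 to compound 2 (0.44 log units; beyond the scatter), so the larger group weakened inhibition modestly.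

The two changes are of the same kind but not the same. In the earlier pair the carbon that receives the methyl is bound to an oxygen on an aromatic ring and a saturated chain carbon, so ethoxy becomes isopropoxy; in the new pair it is bound only to an oxygen on an aromatic ring, so methoxy becomes ethoxy. Beyond that, compound 3 and compound 1 differ in more than one place, and the difference between the two cores is not broken down here. Of the measured compounds, compound 3 stands highest, beyond the scatter from both others.

For the measured compounds named here, with only one earlier step, made on a different core and at a slightly different place, the expectation is loose. The earlier step from compound 1 to compound 2 suggests that adding the methyl tends to raise the number, so compound 4 is expected to land somewhat above compound 3, by about a 1.5-fold higher number from compound 3 to compound 4 (0.17 log units; within the scatter). The estimated value for compound 4 in this assay is 4000 nM, with a likely range from 1500 nM to 10000 nM.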

Compound 4, half-maximal inhibitory concentration: 1580 nM
Compound 4: the middle estimate sits 2.5-fold (0.40 log units) above what was measured; measured number inside the range.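

In this assay, turning methoxy into ethoxy gives a 1.7-fold lower number from compound 3 to compound 4 (0.23 log units; within the scatter), so this pair cannot be told apart, even though the same methyl was added as in the earlier pair. Set side by side, the two steps show that this added methyl does not carry over as a fixed shift from one core to the other in this series: the same change on two cores in this assay, a 2.8-fold higher number (0.44 log units; beyond the scatter) from compound 1 to compound 2 and a 1.7-fold lower number (0.23 log units; within the scatter) from compound 3 to compound 4, 4.7-fold (0.67 log units) apart, beyond the scatter of two such steps What this does not show is why the two steps differ, since the methyl lands on a different carbon in each pair (ethoxy becomes isopropoxy in one, methoxy becomes ethoxy in the other) and the two cores differ in more than one place, so the core and the exact site of the change cannot be separated, and with one pair on each core no rule can be drawn for other cores.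

Still open, from the compounds shown here alone, is whether isopropoxy in place of ethoxy on the core of compound 4 would repeat the earlier step, which would help to separate the role of the core from that of the site. Also open, going by these compounds, is how a longer chain such as butoxy, or an amine or a carboxylic acid in place of the ethoxy group, would behave in this assay.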